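Swapping Chloro for Methyl at the Limit of Detection

A few compounds are considered here, and "the series" means these few. Any claim that something is new, unique, unknown or untested is made for them only; others in the source may bear on it.

Measured so far in an assay on isolated protein for binding affinity to corticotropin-releasing factor receptor 1 (Homo sapiens); on this read-out lower numbers stand for stronger inhibition and higher numbers for weaker inhibition:
compound 1, `CC(=O)/C(=N\Nc1ccccc1[N+](=O)[O-])N(C)c1cccc(Cl)c1`, gives 8600 nM.
compound 2, `CC(=O)/C(=N\Nc1ccccc1)N(C)c1cccc(Cl)c1`, gives only a limit of > 10000 nM.
compound 3, `CC(=O)/C(=N\Nc1ccccc1Cl)N(C)c1cccc(Cl)c1`, gives only a limit of > 10000 nM.

Compound 3 thus stands at the limit of this assay, (the limit of > 10000 nM in this assay, at which 2 of the 3 values shown sit), and no number is known for it. Compound 4, `CC(=O)/C(=N\Nc1ccccc1C)N(C)c1cccc(Cl)c1`, differs from compound 3 by methyl in place of chloro on an aromatic carbon. Of the measured steps, an at least 1.1-fold higher number from compound 1 to compound 2 (0.06 log units; that floor lies within the scatter) and an at least 1.1-fold higher number from compound 1 to compound 3 (0.06 log units; that floor lies within the scatter) each replace the nitro group on the same aromatic carbon and each run into the limit, and a step that the two limits leave unreadable from compound 2 to compound 3 cannot be read at all. Among the measured compounds shown here, no measured step exchanges chloro for methyl, so the size of the step to compound 4 has no direct precedent. For the measured compounds named here, with two of three values at the limit and the one number not far from it, compound 4 is expected to stay near the limit, and the step that the limit leaves unreadable from compound 3 to compound 4 is estimated to be small or not readable. Compound 4 is therefore estimated at 12000 nM in this assay, with a range from 4000 nM to 40000 nM.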

Compound 4, inhibition constant: > 10000 nM
Compound 4: no number, only a limit; the forecaster's own chance of this, stated with the estimate: 70%; the middle value does not contradict the limit.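

In this assay compound 4 gives > 10000 nM, a limit and not a number, so methyl joins hydrogen and chloro at this place, on an aromatic carbon ortho to a large group, without yielding a measurable value. Compound 1, with nitro, remains the only one of the four with a number, yet methyl in place of nitro gives only an at least 1.1-fold higher number from compound 1 to compound 4 (0.06 log units; that floor lies within the scatter), which does not show that nitro is the better group. The steps to compound 4 from compound 2 and from compound 3 cannot be read because both ends of each sit at a limit: the limit of > 10000 nM in this assay, at which 3 of the 4 values shown sit.

As far as these compounds go, how far hydrogen, chloro and methyl truly lie from one another stays open. So does whether an amine, a carboxylic acid or a methoxy group at this place would give a number.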